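The source may report more compounds than this note shows. Statements on the series, on what has been measured and on what is new or still open speak of the compounds shown alone.

Measured so far:
- compound 1, `COc1ccc(C(=O)c2ccc3c(c2)C(n2ccccc2=O)=CC(C)(C)O3)cc1`, 5.72 in a functional assay (trachea) with Rattus norvegicus as the target; on this read-out lower numbers stand for lower potency and higher numbers for higher potency (the scale is a negative logarithm)
- compound 2, `CC1(C)C=C(n2ccccc2=O)c2cc(C(=O)c3ccc(O)cc3)ccc2O1`, 5.87
- compound 3, `CC1(C)C=C(n2ccccc2=O)c2cc(C(=O)c3ccccc3[N+](=O)[O-])ccc2O1`, 5.64

Going by the values given here, of the three numbers in this assay, the one for compound 3 is the lowest, yet the steps of a number 0.08 log units lower from compound 1 to compound 3 (within the scatter) and a number 0.23 log units lower from compound 2 to compound 3 (within the scatter) are both within the scatter, so the three compounds cannot be told apart on these data. The unmeasured compound 4, `Cc1ccccc1C(=O)c1ccc2c(c1)C(n1ccccc1=O)=CC(C)(C)O2`, is reached from compound 3 by the change (methyl in place of nitro on an aromatic carbon). Its place is on an aromatic carbon of a six-membered aromatic ring of carbon only. The two steps that bear on it, a number 0.08 log units lower from compound 1 to compound 3 (within the scatter) and a number 0.23 log units lower from compound 2 to compound 3 (within the scatter), each swap one aryl group on the carbonyl carbon for another, and neither moved the number beyond the scatter. Among the compounds with values here, no measured step swaps nitro for methyl directly, so the expectation rests on those two swaps alone, and the expected step of a number 0.06 log units higher from compound 3 to compound 4 (within the scatter) is none beyond the scatter. Compound 4 is therefore estimated at 5.7, with a range from 5.2 to 6.2.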

Compound 4, logarithm of the reciprocal of the active concentration, log(1/C): 6.25
Estimate against measurement, compound 4: 0.55 log units below; measured number outside the range, above it.
By their numbers in this assay, from the lowest: compounds 3, 1 and 2 (each within the scatter of the next); then compound 4.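

In this assay, going by these compounds alone, this position responds to the choice of group: with a number 0.61 log units higher from compound 3 to compound 4 (beyond the scatter), methyl in place of nitro gives the first step beyond the scatter. Within the data shown here, the gain also separates compound 4 from the other two compounds, with a number 0.38 log units higher from compound 2 to compound 4 (beyond the scatter) and a number 0.53 log units higher from compound 1 to compound 4 (beyond the scatter), so 2-methylphenyl is the one aryl group on the carbonyl carbon that stands clear of the others, and compound 4 is the most potent of the four. Nothing available explains why this change raises the number.

As far as these compounds go, it remains open how an ethyl group, a chlorine atom or an amine on the same aromatic carbon would compare with methyl. Also open, from the compounds shown here alone, is where a plain phenyl on the carbonyl carbon would fall.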